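Swapping a pyridine for a lactam ring on the shared core

This account rests on a few compounds, and the source may have more. Where it says the series, first, only, none or still open, it means among the compounds named here.

Compound 3 (`O=C(O)c1ccc2noc(-c3ccc(-c4ccncc4)cc3)c2c1`) carries an acid group on the shared core and a pyridin-4-yl group on a six-membered aromatic ring of carbon only. Going by the values given here, in an assay for inhibition of inositol hexakisphosphate kinase 3 (Homo sapiens), read by colorimetric assay, coupled enzyme assay and malachite green, with a stated time of 120 min, in the presence of a further agent that is not named here (on this read-out higher numbers stand for weaker inhibition and lower numbers for stronger inhibition), compound 3 gives 670 nM, the lowest of the three numbers measured so far. The nearest neighbour is compound 1 (`Cc1cccc(-c2onc3ccc(/C=C/C(=O)O)cc23)c1`), which in this assay gives 3590 nM; the furthest is compound 2 (`CNC(=O)c1ccc2noc(-c3ccccc3)c2c1`), which gives 6830 nM. Both gaps lie beyond the usual scatter, so compound 3 is the strongest inhibitor of the three.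

Compound 4 (`O=C(O)c1ccc2noc(-c3ccc(N4CCCC4=O)cc3)c2c1`) keeps the acid and the shared core but changes the outer group: 2-oxopyrrolidin-1-yl in place of pyridin-4-yl on an aromatic carbon. Among the compounds with values here, no measured pair shows an exchange of this kind, so its effect can only be estimated. The expected step is a 2.2-fold higher number from compound 3 to compound 4 (0.35 log units; beyond the scatter), a modest move toward weaker inhibition. Compound 4 is therefore estimated at 1500 nM in this assay, with an expected range from 500 nM to 5000 nM.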

Compound 4, half-maximal inhibitory concentration: 2170 nM
Beside the measured number, compound 4's estimate is 1.4-fold (0.16 log units) below it; the range from low to high includes it.
By their numbers in this assay, from the lowest: compound 3; then compounds 4, 1 and 2 (each within the scatter of the next, the first and the last beyond it).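

The first exchange measured at this place, on an aromatic carbon para to a large group, gives a 3.2-fold higher number from compound 3 to compound 4 (0.51 log units; beyond the scatter) in this assay. The number therefore responds to the kind of ring here, even though pyridin-4-yl and 2-oxopyrrolidin-1-yl have the same count of heavy atoms, the same count of hydrogen-bond acceptors and no net charge. Nothing measured here explains why the number moves.

On these data alone, it remains open whether a pyrrolidin-1-yl group, which lacks the carbonyl, would give a number nearer that of compound 3 or that of compound 4. A pyridin-3-yl group would show whether the place of the ring nitrogen matters as well.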